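This account rests on a few compounds, and the source may have more. Where it says the series, first, only, none or still open, it means among the compounds named here.

Compound 1 (`COc1ccc(NCCNc2ccnc3cc(Cl)ccc23)cc1`) stands only at a limit in a toxicity assay on Huh-7 cells (Homo sapiens) for cytotoxicity, read by MTT assay, with a stated time of 72 h; on this read-out lower numbers stand for higher toxicity in this test and higher numbers for lower toxicity in this test: in this assay compound 1 gives > 100 ug/mL, which is a limit of the test and not a number. Compound 2 (`Cc1ccc(NCCNc2ccnc3cc(Cl)ccc23)cc1`) behaves the same way, giving > 100 ug/mL in this assay, again a limit. The step that the two limits leave unreadable from compound 1 to compound 2 therefore cannot be sized, because of the limit of > 100 ug/mL in this assay, at which 2 of the 2 values shown sit. Compound 3 (`COc1ccc(NCCNc2ccnc3cc(Cl)ccc23)cc1OC`) differs from compound 1 by methoxy in place of hydrogen on an aromatic carbon. No measured step bears on this particular change, and the one step shown, methyl in place of methoxy, is itself unreadable. One therefore expects no step beyond the scatter in this assay, and the result will most probably again be reported only as a limit; the estimated step is a step that the limit leaves unreadable from compound 1 to compound 3. Compound 3 is thus expected to give about 120 ug/mL in this assay, within a range from 70 ug/mL to 200 ug/mL.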

Compound 3, half-maximal cytotoxic concentration: > 100 ug/mL
Compound 3 ended at the assay's limit; the forecaster's own chance of this, stated with the estimate: 85%; the middle value lies beyond the limit too.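

No step can be read from compound 1 to compound 3, as both compounds stand only at a limit of the test: the limit of > 100 ug/mL in this assay, at which 3 of the 3 values shown sit. The compounds shown leave open how far their toxicity in this assay differs from one compound to another, and so what methoxy in place of hydrogen does there.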